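This account rests on a few compounds, and the source may have more. Where it says the series, first, only, none or still open, it means among the compounds named here.

In an ADME assay on MRC5 cells (Homo sapiens) for cytotoxicity, read by fluorescence, with a stated time of 72 h (a higher number here means a weaker inhibitor, a lower number a stronger inhibitor), compound 1 `CC1(COc2ccc(OC(F)(F)F)cc2)Cn2cc([N+](=O)[O-])nc2O1` gives > 64000 nM, which is a limit of the assay. For the measured compounds named here, compound 2 `CC1(COc2ccc(OC(F)(F)F)cc2)Cn2cc(Br)nc2O1` gives 34000 nM, the only actual number so far. Compound 3 `CC1(COc2ccc(OC(F)(F)F)cc2)Cn2cc(C=O)nc2O1` differs from it by formyl in place of bromo on an aromatic carbon. Going by the values given here, the sole measured step, bromo in place of nitro on an aromatic carbon, is an at least 1.8-fold lower number from compound 1 to compound 2 (0.27 log units; that floor lies within the scatter), so no change beyond the scatter is expected in this assay. The expected step is a 1.2-fold lower number from compound 2 to compound 3 (0.08 log units; within the scatter). Compound 3 is estimated at 28000 nM, with an expected range of 9000 nM to 64000 nM.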

Compound 3, half-maximal inhibitory concentration: > 64000 nM
Compound 3: a limit, no number; the forecaster's own chance of this, stated with the estimate: 15%; middle value at least 2.2-fold (0.35 log units) from the limit.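

Formyl in place of bromo on this aromatic carbon in this assay gives an at least 1.8-fold higher number from compound 2 to compound 3 (0.27 log units; that floor lies within the scatter) and so shows no change beyond the scatter. For the compounds shown here, compound 3 carries a limit and not a number, which leaves compound 2 as the only compound here with an actual number. The step between compound 1 and compound 3 cannot be read, and the ceiling of the assay restricts what these compounds can show: the limit of > 64000 nM in this assay, at which 2 of the 3 values shown sit.

Still open, on these data alone, is whether an amine or a carboxylic acid on this aromatic carbon would give a number that lies beyond the scatter from compound 2.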